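The source may report more compounds than this note shows. Statements on the series, on what has been measured and on what is new or still open speak of the compounds shown alone.

In an ADME assay on MCF-10A cells (Homo sapiens) for cytotoxicity, read by MTT assay, with a stated time of 24 h (on this read-out higher numbers stand for weaker inhibition and lower numbers for stronger inhibition), compound 1 `FC(F)(F)Oc1ccc(-c2cc(COc3ccccc3-c3nc4ccccc4s3)on2)cc1` gives 43900 nM, the highest of the two numbers recorded so far. For the measured compounds named here, the only other measured compound, compound 2 `Fc1ccc(-n2cc(COc3ccccc3-c3nc4ccccc4s3)nn2)cc1`, gives 33300 nM in this assay, and the gap between these two values lies within the scatter of repeated measurements, so the two compounds cannot be told apart on this read-out.

Compound 3 `Clc1ccc(-c2cc(COc3ccccc3-c3nc4ccccc4s3)on2)cc1` has not yet been measured. It differs from compound 1 by one change: chloro in place of trifluoromethoxy on an aromatic carbon. Going by the values given here, no pair of measured compounds shows this particular change, so there is no measured step to lean on. The two measured values are close to each other, and nothing in them points toward a shift in either direction for this kind of substitution on the outer ring.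

The expectation for compound 3 is therefore a number close to that of compound 1, with the step from compound 1 to compound 3 estimated as a 1.1-fold lower number from compound 1 to compound 3 (0.04 log units; within the scatter), no larger than the scatter. Compound 3 is expected to give about 40000 nM in this assay, with a plausible range from 20000 nM to 80000 nM.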

Compound 3, half-maximal inhibitory concentration: 38800 nM
Beside the measured number, compound 3's estimate is 1.0-fold (0.01 log units) above it; measured number inside the range.
By their numbers in this assay, from the lowest: compounds 2, 3 and 1 (each within the scatter of the next).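

For the compounds shown here, replacing the 4-(trifluoromethoxy)phenyl group with 4-chlorophenyl provides the first single-place comparison: in this assay, the result is a 1.1-fold lower number from compound 1 to compound 3 (0.05 log units; within the scatter). At this position, on an aromatic carbon of a six-membered aromatic ring of carbon only and para to a large group, a five-atom trifluoromethoxy group with one hydrogen-bond acceptor and a single chlorine atom with none cannot be told apart on this read-out. The data therefore show that, for this one pair, the difference in size and acceptor count does not produce a measurable separation, although nothing available explains that result.

Going by these compounds alone, this single comparison covers only two groups at this position, so it remains open whether an amine, a carboxylic acid or a longer alkyl chain there would also leave the number within the scatter or would separate clearly from compound 1. On these data alone, it is also open whether the same exchange would give a similar result on the core of compound 2, which differs from compound 1 in more than one place and so offers no direct comparison.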